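The source may report more compounds than this note shows. Statements on the series, on what has been measured and on what is new or still open speak of the compounds shown alone.

In a physicochemical assay for lipophilicity, read by HPLC, measured as chromatographic lipophilicity, at pH 7.4 (a lower number here means a more polar compound, a higher number a more lipophilic compound), compound 1 `O=C(C1CCOC1)N1N=CCC1c1ccccc1` gives 3 and compound 2 `O=C(c1ccncc1)N1N=CCC1c1ccccc1` gives 2.7, so these two values lie within the scatter of each other. Compound 3 `O=C(C1CCOCC1)N1N=CCC1c1ccccc1` carries oxan-4-yl in place of pyridin-4-yl on a carbonyl carbon. For the measured compounds named here, the one measured step that bears on this change is a number 0.30 log units lower from compound 1 to compound 2 (within the scatter), which puts pyridin-4-yl in place of oxolan-3-yl. Swapping pyridin-4-yl back out for a non-aromatic ring should give a similarly small move in the opposite direction in this assay, so the expected step is a number 0.40 log units higher from compound 2 to compound 3 (beyond the scatter). Compound 3 is estimated at 3.1, within a range of 2.8 to 3.4.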

Compound 3, distribution coefficient: 3.1
For compound 3 middle estimate and measured number coincide at the digits printed; the measured number falls inside the stated range.
By their numbers in this assay, from the lowest: compounds 2, 1 and 3 (each within the scatter of the next, the first and the last beyond it).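

In this assay, for the compounds shown here, the step of a number 0.40 log units higher from compound 2 to compound 3 (beyond the scatter) is the first at this carbonyl carbon to lie beyond the scatter, for a swap of aromatic pyridin-4-yl for non-aromatic oxan-4-yl with the same number of heavy atoms. The step of a number 0.10 log units higher from compound 1 to compound 3 (within the scatter) stays within the scatter, so the two non-aromatic rings are not told apart, while compound 1 against compound 2 shows that a non-aromatic ring does not always separate from pyridin-4-yl. Nothing available explains these numbers.

Open, as far as these compounds go, is how phenyl, with no ring hetero atom, or piperidin-4-yl, which carries an amine, would read at this carbonyl carbon.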